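The source may report more compounds than this note shows. Statements on the series, on what has been measured and on what is new or still open speak of the compounds shown alone.

Working notes on the series. Compound 1 `CCSC(=O)C1=C(C)NC(=O)NC1c1ccsc1` and compound 2 `CCC(C)OC(=O)C1=C(C)NC(=O)NC1c1ccsc1` share one core and differ only in the group on the carbonyl carbon. In an assay on membranes from HeLa cells for displacement of a labelled ligand from adenosine receptor A3 (Homo sapiens), read by scintillation counting, with a stated time of 180 min, tested at 1 uM (a lower number here means less inhibition, a higher number more inhibition at the concentration tested (going by the name of the read-out)), compound 1 gives 2%. In this assay compound 2 gives 7%. Among the compounds with values here, the single measured step, a number 5 percentage points higher from compound 1 to compound 2 (within the scatter), shows the exchange of sec-butoxy for ethylsulfanyl on the carbonyl carbon left the read-out unchanged within the scatter; compound 2 therefore stands alongside compound 1 at a low level of inhibition, with no ordering between the two.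

Compound 3 `CC1=C(C(=O)OC2CCC2)C(c2ccsc2)NC(=O)N1` differs from compound 2 by cyclobutyl in place of sec-butyl on an oxygen next to a carbonyl group. Within the data shown here, the only measured step that bears on this change is a number 5 percentage points higher from compound 1 to compound 2 (within the scatter), which altered the same part of the molecule and stayed within the scatter. With nothing in the two measured compounds pointing to a movement beyond the scatter, the step of a number 1 percentage points lower from compound 2 to compound 3 (within the scatter) is expected to stay within it, in no particular direction. Compound 3 is estimated at 6% in this assay, with a range from -4% to 16%.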

Compound 3, a percentage reported as inhibition, at one concentration (the size of the read-out at that concentration, not a potency): 3%
The estimate for compound 3 lay 3 percentage points above the measured number; low and high end bracket the measured number.
By their numbers in this assay, from the lowest: compounds 1, 3 and 2 (each within the scatter of the next).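

Cyclobutyl in place of sec-butyl on an oxygen next to a carbonyl group brings a four-membered ring to this place while the count stays at 4 heavy atoms, and in this assay the step, a number 4 percentage points lower from compound 2 to compound 3 (within the scatter), shows that closing the chain into a ring does not move the read-out beyond the scatter. Set against the thioester-type starting point, the step of a number 1 percentage points higher from compound 1 to compound 3 (within the scatter), places cyclobutyloxy on the carbonyl carbon level with ethylsulfanyl, so that ethylsulfanyl, sec-butoxy and cyclobutyloxy now all sit within the scatter of one another at a low level of inhibition, with no ordering among them. No supporting measurement is available that would explain this flat result.

The three compounds leave open whether any group on the carbonyl carbon can raise inhibition beyond the scatter, since only small carbon groups joined through oxygen or sulfur appear here, and a free carboxylic acid, an amide built from an amine, or a longer chain ending in a phenyl ring would test that. Also open is whether the low level belongs to the shared core itself, as every compound shown carries it unchanged and only one concentration is reported.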